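This account rests on a few compounds, and the source may have more. Where it says the series, first, only, none or still open, it means among the compounds named here.

Measured so far:
compound 1 `C=CCNC(=O)/C(C)=C(\C)c1ccc(Cl)cc1` — 18.6 mg/kg
compound 2 `C/C(C(=O)NC1CC1)=C(/C)c1ccccc1` — 55.9 mg/kg

In a functional assay on the whole organism with Mus musculus as the target (a lower number here means that less compound is needed, a higher number that more compound is needed for the effect), compound 1 gives 18.6 mg/kg and compound 2 gives 55.9 mg/kg. Compound 2 thus holds the higher of the two numbers, and its gap to compound 1 lies beyond the scatter. Compound 3 `C=CCNC(=O)/C(C)=C(\C)c1ccccc1` is not yet measured. It differs from compound 2 by allyl in place of cyclopropyl on an amide-type nitrogen. Among the measured compounds shown here, no step between measured compounds isolates this change, since compound 1 differs from compound 3 elsewhere as well. A moderate downward step is expected in this assay, namely a 1.9-fold lower number from compound 2 to compound 3 (0.27 log units; within the scatter), possibly within the scatter. For compound 3 the estimate is 30 mg/kg, with a range from 12 mg/kg to 75 mg/kg.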

Compound 3, dose for half-maximal effect: 67 mg/kg
The estimate for compound 3 lay 2.2-fold (0.35 log units) below the measured number; measured number inside the range.
By their numbers in this assay, from the lowest: compound 1; then compounds 2 and 3 (each within the scatter of the next).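

In this assay the step of a 1.2-fold higher number from compound 2 to compound 3 (0.08 log units; within the scatter) shows that on the amide-type nitrogen, allyl in place of cyclopropyl removes the three-membered ring without moving the number beyond the scatter. Among the compounds shown here, the step of a 3.6-fold higher number from compound 1 to compound 3 (0.56 log units; beyond the scatter) isolates the chloro group for the first time: with the allyl amide held constant, hydrogen in place of chloro on the aromatic carbon gives a higher number. No measured evidence bears on the cause of either step.

From the compounds shown here alone, it remains open whether the chloro step carries over to the cyclopropyl amide. Also open, going by these compounds, is how fluoro or methoxy on the aromatic carbon, or a longer chain on the amide-type nitrogen, would read.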